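The source may report more compounds than this note shows. Statements on the series, on what has been measured and on what is new or still open speak of the compounds shown alone.

Compounds measured in a functional assay on cells (Homo sapiens) for antiproliferative activity, read by WST assay, with a stated time of 3 days; on this read-out higher numbers stand for weaker inhibition and lower numbers for stronger inhibition:
Compound 1 `N#Cc1cc(=O)[nH]c(=O)n1[C@@H]1O[C@H](CO)[C@@H](O)[C@H]1O`; in this assay compound 1 gives > 50000 nM, which is a limit of the assay.
Compound 2 `[N-]=[N+]=Nc1cc(=O)[nH]c(=O)n1[C@@H]1O[C@H](CO)[C@@H](O)[C@H]1O`; compound 2 gives > 50000 nM, again a limit.
Compound 3 `COC(=O)c1cc(=O)[nH]c(=O)n1[C@@H]1O[C@H](CO)[C@@H](O)[C@H]1O`; compound 3 gives 42300 nM.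

Going by the values given here, compound 3 thus stands as the only actual number among the three values; the other two sit at the limit of > 50000 nM in this assay, at which 2 of the 3 values shown sit. Compound 4 `CNc1cc(=O)[nH]c(=O)n1[C@@H]1O[C@H](CO)[C@@H](O)[C@H]1O` differs from compound 3 by methylamino in place of methoxycarbonyl on an aromatic carbon. Among the compounds with values here, the steps that bear on this change are an at least 1.1-fold lower number from compound 1 to compound 3 (0.07 log units; that floor lies within the scatter) and an at least 1.1-fold lower number from compound 2 to compound 3 (0.07 log units; that floor lies within the scatter), each only a floor within the scatter and unreadable beyond it because the limit of > 50000 nM in this assay, at which 2 of the 3 values shown sit, caps compounds 1 and 2. For compound 4 no step beyond the scatter is therefore expected, a 1.2-fold higher number from compound 3 to compound 4 (0.07 log units; within the scatter). Compound 4 is estimated at 50000 nM, with a range from 15000 nM to 200000 nM.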

Compound 4, half-maximal inhibitory concentration: > 50000 nM
Compound 4: a limit, no number (the forecaster's own chance of this, stated with the estimate: 60%); the middle value sits exactly at the limit.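

Methylamino in place of methoxycarbonyl on this aromatic carbon gives an at least 1.1-fold higher number from compound 3 to compound 4 (0.07 log units; that floor lies within the scatter) in this assay and so adds no readable change at this position. The steps from compound 1 and from compound 2 to compound 4 cannot be read. Compound 3 remains the only one of the four with an actual number, and no group at this position is clearly set apart from another: the limit of > 50000 nM in this assay, at which 3 of the 4 values shown sit.

Going by these compounds, whether a carboxylic acid, an unsubstituted amine or a longer ester chain here would give a number clearly lower than that of compound 3 in this assay stays open.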